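The source may report more compounds than this note shows. Statements on the series, on what has been measured and on what is new or still open speak of the compounds shown alone.

Compound 1 `OC(c1ccc(Cl)cc1)(c1cccnc1)c1ccccc1F` only reaches a limit of the assay, > 100000 nM, in an ADME assay on L6 cells (Rattus norvegicus) for cytotoxicity, read by resazurin assay, with a stated time of 72 h; on this read-out higher numbers stand for weaker inhibition and lower numbers for stronger inhibition. Compound 2 `Cc1ccccc1C(O)(c1ccc(Cl)cc1)c1cccnc1` gives 82000 nM in this assay.

Within the data shown here, compound 2 therefore stands as the only true number here, while compound 1 sits at the limit of > 100000 nM in this assay, at which 1 of the 2 values shown sits. Among the measured compounds shown here, the single measured step, an at least 1.2-fold lower number from compound 1 to compound 2 (0.08 log units; that floor lies within the scatter), lies within the scatter. Compound 3 `OC(c1ccc(Cl)cc1)(c1cccnc1)c1cncnc1` differs from compound 2 by pyrimidin-5-yl in place of 2-methylphenyl on a saturated chain carbon bound to two aromatic carbons and an oxygen on a saturated carbon. For the measured compounds named here, no measured step covers this change, so no shift beyond the scatter is expected. Compound 3 is estimated at 90000 nM, between 40000 nM and 200000 nM. That estimate means an expected 1.1-fold higher number from compound 2 to compound 3 (0.04 log units; within the scatter).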

Compound 3, half-maximal inhibitory concentration: > 100000 nM
Compound 3: a limit, no number; the forecaster's own chance of this, stated with the estimate: 50%; at least 1.1-fold (0.04 log units) between middle value and limit.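

Pyrimidin-5-yl in place of 2-methylphenyl swaps a carbon-only ring for one with 2 hydrogen-bond acceptors, and this gives an at least 1.2-fold higher number from compound 2 to compound 3 (0.08 log units; that floor lies within the scatter). So, unlike the earlier swap of one small group on the ring, replacing the whole ring at this position also produces no change that can be told from the scatter. The step from compound 1 to compound 3 cannot be read, and limits now make up most of the series: the limit of > 100000 nM in this assay, at which 2 of the 3 values shown sit.

Going by these compounds, whether any group at this position can produce a clear shift remains open. An amine or a carboxylic acid here could still read differently in this assay.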